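A few compounds are considered here, and "the series" means these few. Any claim that something is new, unique, unknown or untested is made for them only; others in the source may bear on it.

Compounds measured in an assay on isolated protein for displacement of a labelled ligand from corticotropin-releasing factor receptor 1 (Homo sapiens); a lower number here means a stronger inhibitor, a higher number a weaker inhibitor:
- compound 1 `CCCC(CC)Nc1nc(C)nc2c(-c3ccc(Cl)cc3Cl)c(C)nn12` gives 1.2 nM
- compound 2 `CCN(CC)c1nc(C)nc2c(-c3ccc(Cl)cc3Cl)c(C)nn12` gives 1.2 nM

Compound 2 stands level with compound 1 in this assay; the step from one to the other is no change at the digits printed from compound 1 to compound 2 (within the scatter), so the two cannot be ranked. The next step leads to compound 3 `CCCC(CCC)Nc1nc(C)nc2c(-c3ccc(Cl)cc3Cl)c(C)nn12`, which differs from compound 2 in one place: (1-propylbutyl)amino in place of diethylamino on an aromatic carbon. For the measured compounds named here, only one measured step bears on this change, and it is the mirror of it: going from compound 1 to compound 2 exchanged (1-ethylbutyl)amino for diethylamino with no change at the digits printed from compound 1 to compound 2 (within the scatter). Compound 3 returns to a branched secondary alkylamino group of the same kind as that of compound 1, with (1-propylbutyl)amino in the same place. Since the forward exchange moved nothing beyond the scatter, the return is expected to move nothing beyond it either, in neither direction, so that the step from compound 2 to compound 3 is estimated as a 1.1-fold higher number from compound 2 to compound 3 (0.03 log units; within the scatter). Compound 3 is therefore expected to give about 1.3 nM in this assay, with a range from 0.4 nM to 4 nM.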

Compound 3, inhibition constant: 1.6 nM
The estimate for compound 3 lay 1.2-fold (0.09 log units) below the measured number; measured number inside the range.
By their numbers in this assay, from the lowest: compounds 1, 2 and 3 (each within the scatter of the next).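

In this assay this position, on an aromatic carbon between two ring nitrogen atoms, takes a group of 8 heavy atoms in place of one of 5, and a group with 1 hydrogen-bond donor in place of one with none, with a step of a 1.3-fold higher number from compound 2 to compound 3 (0.12 log units; within the scatter). Within the branched secondary alkylamino groups, adding one methyl to the chain of (1-ethylbutyl)amino to give (1-propylbutyl)amino amounts to a 1.3-fold higher number from compound 1 to compound 3 (0.12 log units; within the scatter), so the three amino groups shown cannot be ranked by size or branching. Nothing on hand explains why these exchanges leave the number within the scatter.

The compounds shown leave open how far this freedom extends, since all three groups are open-chain alkylamino groups: a much longer chain such as (1-pentylhexyl)amino, a ring amine such as morpholine, or an unsubstituted amine could each behave differently. It also remains open whether a carboxylic acid or a hydroxyl group at the end of one of these chains would stay level with the three compounds shown.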